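Swapping methoxy for fluoro on a glutamate receptor modulator

A few compounds are considered here, and "the series" means these few. Any claim that something is new, unique, unknown or untested is made for them only; others in the source may bear on it.

Of the compounds shown here, three built on one shared core have been measured in an assay on HEK293 cells for positive allosteric modulation of metabotropic glutamate receptor 3 (Rattus norvegicus), read by thallium flux, with a stated time of 2.5 min; on this read-out lower numbers stand for smaller maximal responses and higher numbers for larger maximal responses. Compound 3 `COc1cc(C(=O)O)ccc1OCCCCOc1ccc(C(=O)CC(C)C)c(O)c1C` gives 73.9%, the highest of the three numbers. Compound 1 `Cc1cc(C(=O)O)ccc1OCCCCOc1ccc(C(=O)CC(C)C)c(O)c1C` gives 42.1%, and compound 2 `Cc1c(OCCCCOc2ccc(C(=O)O)cc2F)ccc(C(=O)CC2CCCC2)c1O` gives 31.2%; both of these stand beyond the scatter below compound 3. For the measured compounds named here, the only measured pair that differs in a single place is a number 31.8 percentage points higher from compound 1 to compound 3 (beyond the scatter), so that step is large.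

Compound 4 `Cc1c(OCCCCOc2ccc(C(=O)O)cc2F)ccc(C(=O)CC(C)C)c1O` takes the next step from compound 3: fluoro in place of methoxy on an aromatic carbon. Going by the values given here, no measured pair isolates fluoro against methoxy at this carbon. The step from compound 1 to compound 3 shows that the group at this carbon moves the number strongly, and compound 2, which also carries a fluoro there but differs elsewhere in its structure, gives a low number. Taken together, loss of the methoxy is expected to give back much of the rise seen in compound 3, with a step of a number 33.9 percentage points lower from compound 3 to compound 4 (beyond the scatter) expected in this assay. Compound 4 is therefore estimated at 40%, likely between 25% and 60%.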

Compound 4, largest response reached (reported as percent of maximum), in percent of the reference or control that the assay uses: 67.7%
For compound 4 the middle estimate is 27.7 percentage points below the measured one; measured number above the stated range.
By their numbers in this assay, from the lowest: compound 2; then compound 1; then compounds 4 and 3 (each within the scatter of the next).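

In this assay, fluoro in place of methoxy on this aromatic carbon gives a number 6.2 percentage points lower from compound 3 to compound 4 (within the scatter), so at this position the two groups cannot be told apart, and the high number does not depend on the methoxy itself. Fluoro in place of methyl at the same carbon gives a number 25.6 percentage points higher from compound 1 to compound 4 (beyond the scatter), which, together with the earlier methoxy step, leaves methyl as the one group of the three that stands apart, with a lower number than the other two. Compound 2 and compound 4 both carry the fluoro, and isopropyl in place of cyclopentyl on a saturated chain carbon bound to a carbonyl carbon gives a number 36.5 percentage points higher from compound 2 to compound 4 (beyond the scatter), so the low number of compound 2 goes with its cyclopentyl and says little about the fluoro.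

Nothing available here explains why methoxy and fluoro end up so close while methyl does not. Still open, from the compounds shown here alone, is how a chloro, a hydroxy or an amino group would compare on this aromatic carbon, and whether the cyclopentyl step would be as large with methoxy in place of fluoro.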